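The source may report more compounds than this note shows. Statements on the series, on what has been measured and on what is new or still open speak of the compounds shown alone.

Working notes on the nitrofuranyl chalcone series, a toxicity assay on Vero cells (Chlorocebus sabaeus) for cytotoxicity; a higher number here means that more compound is tolerated, a lower number that less compound is tolerated.

Compound 1 `O=C(/C=C/c1ccc([N+](=O)[O-])o1)c1ccccc1` gives 444000 nM in this assay. Compound 2 `COc1ccc(C(=O)/C=C/c2ccc([N+](=O)[O-])o2)cc1` gives 571000 nM in this assay, and compound 3 `O=C(/C=C/c1ccc([N+](=O)[O-])o1)c1ccc(OCc2ccccc2)cc1` gives 515000 nM in this assay. Compound 3 stands second highest of the three numbers, with compound 2 nearest (a 1.1-fold lower number from compound 2 to compound 3 (0.04 log units; within the scatter)) and compound 1 furthest (a 1.2-fold higher number from compound 1 to compound 3 (0.06 log units; within the scatter)).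

Compound 4 `O=C(/C=C/c1ccc([N+](=O)[O-])o1)c1ccc(OCc2cccc(Cl)c2)cc1` differs from compound 3 by chloro in place of hydrogen on an aromatic carbon. Going by the values given here, no measured step adds a chloro. The steps that change the substituent on this end of the molecule, a 1.3-fold higher number from compound 1 to compound 2 (0.11 log units; within the scatter), a 1.2-fold higher number from compound 1 to compound 3 (0.06 log units; within the scatter) and a 1.1-fold lower number from compound 2 to compound 3 (0.04 log units; within the scatter), all lie within the scatter, so no step beyond the scatter in this assay is expected here: a 1.0-fold lower number from compound 3 to compound 4 (0.01 log units; within the scatter). Compound 4 is therefore estimated at 500000 nM in this assay, within a range from 250000 nM to 1000000 nM.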

Compound 4, half-maximal cytotoxic concentration: 307000 nM
Beside the measured number, compound 4's estimate is 1.6-fold (0.21 log units) above it; measured number inside the range.
By their numbers in this assay, from the lowest: compounds 4, 1, 3 and 2 (each within the scatter of the next).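

Chloro on this aromatic carbon, the first in the series, still gives no step beyond the scatter in this assay (a 1.7-fold lower number from compound 3 to compound 4 (0.22 log units; within the scatter)). The full (3-chlorobenzyl)oxy group and its 3-chlorophenyl part likewise stay within the scatter (a 1.4-fold lower number from compound 1 to compound 4 (0.16 log units; within the scatter); a 1.9-fold lower number from compound 2 to compound 4 (0.27 log units; within the scatter)), so all four compounds remain one group in this assay. No supporting data bear on this result.

Open, going by these compounds, is whether an amine or a carboxylic acid on this same aromatic carbon would give a step beyond the scatter in this assay.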